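Series notes: chloro to hydrogen steps and compound 4

The source may hold more compounds than are shown below. What is called first, only, known or untested is meant among the compounds shown, and "the series" means these compounds.

Measured so far:
compound 1 `O=c1cc(CSC(=S)N2CCCCC2)oc2cc(Cl)ccc12`: > 25000 nM, a limit of the assay
compound 2 `O=c1cc(CSC(=S)N2CCCCC2)oc2ccccc12`: > 25000 nM, a limit of the assay
compound 3 `O=c1c(Cl)c(CSC(=S)N2CCOCC2)oc2ccccc12`: 4500 nM

In a functional assay on HeLa cells (Homo sapiens) for antiproliferative activity, read by MTT assay, with a stated time of 72 h (on this read-out lower numbers stand for stronger inhibition and higher numbers for weaker inhibition), compound 1 gives > 25000 nM, which is a limit and not a number. Compound 2 gives > 25000 nM, also a limit. For the measured compounds named here, compound 3 gives 4500 nM, the only number among the three. The change hydrogen in place of chloro on an aromatic carbon gives a step that the two limits leave unreadable from compound 1 to compound 2, unreadable because both values sit at the limit of > 25000 nM in this assay, at which 2 of the 3 values shown sit. How the core of compound 3 differs from the core of compound 1 is not broken down here.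

Compound 4 `O=c1cc(CSC(=S)N2CCOCC2)oc2ccccc12` differs from compound 3 by hydrogen in place of chloro on an aromatic carbon. This is the same kind of change as from compound 1 to compound 2, but the place differs: here the carbon is on a six-membered aromatic ring with 1 oxygen, ortho to a group of 1 heavy atom, ortho to a large group and two atoms from the ring oxygen, whereas in compound 1 it is on a ring of carbon only. The measured step gives no size to lean on. Going by the values given here, for compound 4 a step of a 3.3-fold higher number from compound 3 to compound 4 (0.52 log units; beyond the scatter) is expected, towards weaker inhibition, resting only on compound 3 giving 4500 nM as the sole number. Compound 4 is estimated at 15000 nM, between 4000 nM and 25000 nM.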

Compound 4, half-maximal inhibitory concentration: 35600 nM
Compound 4: middle estimate off by 2.4-fold (0.38 log units), on the low side; measured number outside the range, above it.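

In this assay, hydrogen in place of chloro on the aromatic carbon two atoms from the ring oxygen gives a 7.9-fold higher number from compound 3 to compound 4 (0.90 log units; beyond the scatter), with chloro on the side of stronger inhibition. The same exchange on the ring of carbon only, and the exchange of morpholin-4-yl for piperidin-1-yl, are steps that cannot be read, because each involves a compound at a limit of the assay and not a number: the limit of > 25000 nM in this assay, at which 2 of the 4 values shown sit. The change therefore has a size at one place on one core only, and the compounds shown do not tell whether that size carries to another core or another place.

Still open, as far as these compounds go, is how chloro on the carbon two atoms from the ring oxygen reads with piperidin-1-yl on the thiocarbonyl carbon. Also open, from the compounds shown here alone, is how a group other than chloro on that carbon, such as methyl, a nitrile or an amine, reads in this assay.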